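Cell tolerance on replacing phenyl in compound 3

This account rests on a few compounds, and the source may have more. Where it says the series, first, only, none or still open, it means among the compounds named here.

Compound 1 `CNC(=O)[C@H](CC(C)C)NC(=O)[C@@](O)(CCCN(Cc1ccc(Br)cc1)NC(=O)[C@@H](NC(=O)OC)C(C)(C)C)Cc1ccccc1`: > 10000 nM
Compound 2 `CNC(=O)[C@H](C)NC(=O)[C@@](O)(CCCN(Cc1ccc(Br)cc1)NC(=O)[C@@H](NC(=O)OC)C(C)(C)C)Cc1ccccc1`: > 10000 nM
Compound 3 `CNC(=O)[C@@H](NC(=O)[C@@](O)(CCCN(Cc1ccc(-c2ccccc2)cc1)NC(=O)[C@@H](NC(=O)OC)C(C)(C)C)Cc1ccccc1)C(C)(C)C`: > 50000 nM

All three entries from an ADME assay on MT4 cells (Homo sapiens) for cytotoxicity, read by XTT assay, with a stated time of 5 days (a higher number here means that more compound is tolerated, a lower number that less compound is tolerated), are limits and not numbers. Compound 3 stands only at a limit, > 50000 nM. The entries for the three compounds rest on the limit of > 10000 nM in this assay, at which 2 of the 3 values shown sit, and on (the limit of > 50000 nM in this assay, at which 1 of the 3 values shown sits), so no ranking can be read from them.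

Compound 4 `CNC(=O)[C@@H](NC(=O)[C@@](O)(CCCN(Cc1ccc(C#Cc2cccnc2)cc1)NC(=O)[C@@H](NC(=O)OC)C(C)(C)C)Cc1ccccc1)C(C)(C)C` is reached from compound 3 by one change, (2-(pyridin-3-yl)ethynyl in place of phenyl on an aromatic carbon), in words 2-(pyridin-3-yl)ethynyl in place of phenyl on an aromatic carbon. For the measured compounds named here, the only measured step, a step that the two limits leave unreadable from compound 1 to compound 2, lies elsewhere in the molecule and gives no size to carry over. Going by the values given here, with no measured step at this place, no change beyond the usual scatter is expected in this assay, and a further limit is the likeliest report. The expected step is an at least 1.2-fold lower number from compound 3 to compound 4 (0.09 log units; that floor lies within the scatter). Compound 4 is estimated at 40000 nM, with an expected range of 12000 nM to 100000 nM.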

Compound 4, half-maximal cytotoxic concentration: > 50000 nM
Compound 4: only a limit was reported; the forecaster's own chance of this, stated with the estimate: 75%; at least 1.2-fold (0.09 log units) between middle value and limit.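

In this assay no step can be read between compound 3 and compound 4, since both entries are limits and not numbers: the limit of > 50000 nM in this assay, at which 2 of the 4 values shown sit.

The compounds shown leave open whether any group on this aromatic carbon would give a number rather than a limit in this assay.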